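Shortening the selenocyanate chain on compound 3

The source may hold more compounds than are shown below. What is called first, only, known or untested is meant among the compounds shown, and "the series" means these compounds.

Compound 1 `COc1ccc(N(C)c2nc(C)nc3ccccc23)cc1OCCN`: 421 nM
Compound 2 `COc1ccc(N(C)c2nc(C)nc3ccccc23)cc1OCCCCCC[Se]C#N`: 8580 nM
Compound 3 `COc1ccc(N(C)c2nc(C)nc3ccccc23)cc1C(=O)OCCCC[Se]C#N`: 1080 nM

In a functional assay on LoVo cells (Homo sapiens) for inhibition, read by MTT assay, with a stated time of 48 h (a higher number here means a weaker inhibitor, a lower number a stronger inhibitor), compound 3 stands second highest of the three numbers; the nearest is compound 1, with a 2.6-fold higher number from compound 1 to compound 3 (0.41 log units; beyond the scatter), and the furthest is compound 2, with a 7.9-fold lower number from compound 2 to compound 3 (0.90 log units; beyond the scatter). Compound 4 `COc1ccc(N(C)c2nc(C)nc3ccccc23)cc1C[Se]C#N` differs from compound 3 by a group of 4 heavy atoms (2 carbon, 1 nitrogen, 1 selenium; no ring) in place of a group of 10 heavy atoms (6 carbon, 1 nitrogen, 2 oxygen, 1 selenium; no ring), on an aromatic carbon. For the measured compounds named here, two measured steps bear on this: the long selenocyanate chain of compound 2 gave a 20-fold higher number from compound 1 to compound 2 (1.31 log units; beyond the scatter), a large step, while the shorter ester linker of compound 3 gave a 7.9-fold lower number from compound 2 to compound 3 (0.90 log units; beyond the scatter). The change to compound 4 shortens that chain further, so a modest step toward a lower number, or none beyond the scatter, is expected. For compound 4 the estimate is 700 nM, within 200 nM to 2500 nM, which means a 1.5-fold lower number from compound 3 to compound 4 (0.19 log units; within the scatter).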

Compound 4, half-maximal inhibitory concentration: 277 nM
Compound 4: the middle estimate sits 2.5-fold (0.40 log units) above what was measured; measured number inside the range.
By their numbers in this assay, from the lowest: compounds 4 and 1 (each within the scatter of the next); then compound 3; then compound 2.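

In this assay, cutting the selenocyanate chain down to the group of 4 heavy atoms on this aromatic carbon gave a 3.9-fold lower number from compound 3 to compound 4 (0.59 log units; beyond the scatter) and, against the longest chain, a 31-fold lower number from compound 2 to compound 4 (1.49 log units; beyond the scatter). A selenocyanate group here thus no longer stands apart from the amine chain of compound 1, with a 1.5-fold lower number from compound 1 to compound 4 (0.18 log units; within the scatter) as the gap. From the compounds shown here alone, what remains open is whether a chain of intermediate length without the ester, or an amine or a carboxylic acid on this same aromatic carbon, would give a similar number. No measurement shown explains these steps.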